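Halogen swap on a benzyl ring of a nitrile-bearing core

This account rests on a few compounds, and the source may have more. Where it says the series, first, only, none or still open, it means among the compounds named here.

Compound 1 `N#Cc1c(Nc2ccc(Cl)cc2)nc(SCc2cn(Cc3ccccc3Cl)nn2)nc1-c1ccccc1` gives 5850 nM in a functional assay on MGC-803 cells (Homo sapiens) for inhibition, read by MTT assay, with a stated time of 72 h (a higher number here means a weaker inhibitor, a lower number a stronger inhibitor), and compound 2 `N#Cc1c(Nc2ccc(F)cc2)nc(SCc2cn(Cc3ccccc3Cl)nn2)nc1-c1ccccc1` gives 8740 nM in this assay. Compound 2 differs from compound 1 by fluoro in place of chloro on an aromatic carbon, a change that produced a 1.5-fold higher number from compound 1 to compound 2 (0.17 log units; within the scatter). Compound 3 `Cc1ccc(Nc2nc(SCc3cn(Cc4ccc(Cl)cc4)nn3)nc(-c3ccccc3)c2C#N)cc1` gives 19600 nM in this assay, the highest number of the three; the difference between its core and that of compound 1 is not broken down here. Compound 4 `Cc1ccc(Nc2nc(SCc3cn(Cc4ccc(F)cc4)nn3)nc(-c3ccccc3)c2C#N)cc1` differs from compound 3 by fluoro in place of chloro on an aromatic carbon, the same change seen between compound 1 and compound 2. For compound 4 the step of a 1.3-fold higher number from compound 3 to compound 4 (0.12 log units; within the scatter) is expected, because the same change brought a 1.5-fold higher number from compound 1 to compound 2 (0.17 log units; within the scatter). Compound 4 is therefore estimated to give 26000 nM in this assay, within a range from 12000 nM to 55000 nM.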

Compound 4, half-maximal inhibitory concentration: > 64000 nM
Compound 4: a limit, no number; the forecaster's own chance of this, stated with the estimate: 10%; middle value at least 2.4-fold (0.39 log units) from the limit.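

In this assay compound 4 reads > 64000 nM, which is a limit of the assay and not a number. Fluoro in place of chloro, here 4-chlorobenzyl to 4-fluorobenzyl, gave an at least 3.2-fold higher number from compound 3 to compound 4 (0.51 log units; beyond the scatter), beyond the scatter and in the same direction as a 1.5-fold higher number from compound 1 to compound 2 (0.17 log units; within the scatter), which stays within the scatter. This shows that the direction carried over to the second core, but not that the size of the step carried over or changed: the same change on two cores in this assay, a 1.5-fold higher number (0.17 log units; within the scatter) from compound 1 to compound 2 and an at least 3.2-fold higher number (0.51 log units; beyond the scatter) from compound 3 to compound 4; the limit leaves it open whether they differ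

The compounds shown leave open how a bromo or a methoxy group would read at the same place. They also leave open whether the change would go the same way on a core carrying a carboxylic acid instead of the nitrile.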